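Replacing the 4-(tert-butyl)phenyl group of compound 3

This account rests on a few compounds, and the source may have more. Where it says the series, first, only, none or still open, it means among the compounds named here.

In a functional assay for inhibition, with Homo sapiens as the target (a lower number here means tighter binding, a higher number weaker binding), compound 1 (`N#Cc1ccc(C2OCC(C/C=C\CCC(=O)O)C(c3cccnc3)O2)cc1`) stands at 1290 nM and compound 2 (`CC(C)(Oc1ccccc1)C1OCC(C/C=C\CCC(=O)O)C(c2cccnc2)O1`) at 75.9 nM on the same scale. The change of group on a saturated ring carbon gives a large step (a 17-fold lower number from compound 1 to compound 2 (1.23 log units; beyond the scatter)). Compound 3 (`CC(C)(C)c1ccc(OC(C)(C)C2OCC(C/C=C\CCC(=O)O)C(c3cccnc3)O2)cc1`) at 1910 nM lies within the scatter of compound 1 and far from compound 2. Tert-butyl in place of hydrogen on an aromatic carbon is the only difference on that second comparison (a 25-fold higher number from compound 2 to compound 3 (1.40 log units; beyond the scatter)).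

Compound 4 (`CSc1ccccc1OC(C)(C)C1OCC(C/C=C\CCC(=O)O)C(c2cccnc2)O1`) carries 2-(methylsulfanyl)phenyl in place of 4-(tert-butyl)phenyl on an oxygen on a saturated carbon. Since compound 4 has no tert-butyl group, the step that introduced that group (a 25-fold higher number from compound 2 to compound 3 (1.40 log units; beyond the scatter)) bears most directly. Within the data shown here, no measured compound carries methylsulfanyl, so its own contribution remains unknown. A large step to a lower number is therefore expected in this assay for this change. The expected size is a 27-fold lower number from compound 3 to compound 4 (1.44 log units; beyond the scatter) on this estimate. For compound 4 the estimated value is 70 nM (expected range 18 nM to 300 nM).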

Compound 4, dissociation constant: 89.1 nM
Compound 4: middle estimate off by 1.3-fold (0.10 log units), on the low side; the range from low to high includes it.
By their numbers in this assay, from the lowest: compounds 2 and 4 (each within the scatter of the next); then compounds 1 and 3 (each within the scatter of the next).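

In this assay, not every added group on the phenoxy ring moves the number: methylsulfanyl in place of hydrogen on an aromatic carbon stays within the scatter (a 1.2-fold higher number from compound 2 to compound 4 (0.07 log units; within the scatter)), unlike the tert-butyl step. Exchanging 4-(tert-butyl)phenyl for 2-(methylsulfanyl)phenyl on the oxygen gives a large change (a 21-fold lower number from compound 3 to compound 4 (1.33 log units; beyond the scatter)), so the high number of compound 3 is not shared by every substituted phenoxy compound shown. No measurement in hand accounts for either step.

As far as these compounds go, compound 3 and compound 4 differ in both the group and its place on the aromatic ring, so it stays open which of the two governs the large step. From the compounds shown here alone, how a methoxy group or a chlorine atom on this ring would read is also open.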